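Aryl swap at the benzyl ether of the bicyclic amino diacid

The source may report more compounds than this note shows. Statements on the series, on what has been measured and on what is new or still open speak of the compounds shown alone.

Working notes on a short series of bicyclic amino diacids bearing a benzyl ether. Compound 1 `N[C@]1(C(=O)O)[C@H]2[C@@H](C[C@H]1OCc1cccc(C(F)(F)F)c1)[C@]2(F)C(=O)O` carries a trifluoromethyl on the aromatic ring, and in an assay on CHO cells for binding affinity to metabotropic glutamate receptor 2 (Rattus norvegicus) (on this read-out lower numbers stand for stronger inhibition and higher numbers for weaker inhibition), compound 1 gives 5.72 nM. Compound 2 `N#Cc1cccc(CO[C@@H]2C[C@@H]3[C@H]([C@]2(N)C(=O)O)[C@@]3(F)C(=O)O)c1` carries a cyano in place of that trifluoromethyl, and in this assay compound 2 gives 2.94 nM. Among the measured compounds shown here, the only step measured so far is a 1.9-fold lower number from compound 1 to compound 2 (0.29 log units; within the scatter), so the two compounds cannot be told apart on this read-out.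

Compound 3 `N[C@]1(C(=O)O)[C@H]2[C@@H](C[C@H]1OCc1c(F)cccc1F)[C@]2(F)C(=O)O` is the next member. Against compound 2 the change is 2,6-difluorophenyl in place of 3-cyanophenyl on a saturated chain carbon bound to an oxygen on a saturated carbon. For the measured compounds named here, no measured step exchanges the whole aryl group in this way; the single step available, a 1.9-fold lower number from compound 1 to compound 2 (0.29 log units; within the scatter), only shows that one swap of an aromatic substituent left the number essentially in place. On that basis the expected step from compound 2 to compound 3 is a 1.7-fold higher number from compound 2 to compound 3 (0.23 log units; within the scatter), that is, nothing beyond the scatter. For compound 3 in this assay the estimate is 5 nM, with a plausible range from 1.5 nM to 16 nM.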

Compound 3, inhibition constant: 7.02 nM
The estimate for compound 3 lay 1.4-fold (0.15 log units) below the measured number; the range from low to high includes it.
By their numbers in this assay, from the lowest: compounds 2, 1 and 3 (each within the scatter of the next, the first and the last beyond it).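

Among the compounds shown here, exchanging the whole aryl group at this position gives a 2.4-fold higher number from compound 2 to compound 3 (0.38 log units; beyond the scatter) in this assay, the first step to pass the scatter, though only modestly, and it shows that the number responds to the aryl group at least to this small degree. The comparison is limited to two groups that each hold one six-membered aromatic ring of carbon only, so the step goes with the exchange of 3-cyanophenyl for 2,6-difluorophenyl and with nothing else in the shared core. Nothing on hand bears on the origin of this step, so it stands as an observation only.

Since the nitrile leaves and both fluorines enter in one change, the compounds shown cannot separate the part each plays in the step, and a ring carrying a single fluorine would be needed to divide it. Also open is how the number would respond to an amine or a carboxylic acid on the aromatic ring, since all the ring substituents shown here are uncharged, and whether the narrow spread seen so far would survive such a group.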